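The source may hold more compounds than are shown below. What is called first, only, known or untested is meant among the compounds shown, and "the series" means these compounds.

Measured in a functional assay on NCI-H460 cells (Homo sapiens) for cytotoxicity, read by MTT assay; a higher number here means a weaker inhibitor, a lower number a stronger inhibitor:
compound 1 `COc1cc(CCCCC(C)(C)O)oc(=O)c1C`: > 200000 nM, a limit of the assay
compound 2 `Cc1c(O)cc(CCCC(C)C)oc1=O`: > 200000 nM, a limit of the assay

In this assay compound 1 gives > 200000 nM, which is a limit rather than a number. In this assay compound 2 likewise gives > 200000 nM, again a limit and not a number. Compound 2 therefore stands, among the figures shown, at the limit of > 200000 nM in this assay, at which 2 of the 2 values shown sit, and nothing more can be said of its potency.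

Compound 3 `Cc1c(O)cc(CCCCC(C)[C@H](C)O)oc1=O` has not been measured. It differs from compound 2 in 3-hydroxy-2-methylbutyl in place of isopropyl on a saturated chain carbon, three bonds along the chain from an aromatic carbon. For the measured compounds named here, no step between two measured compounds exists, so the size of this change cannot be read from any precedent here. Since both values shown are limits, the expectation is that the step of a number no higher from compound 2 to compound 3 (the limit leaves the size open) is none beyond the scatter, in either direction. Compound 3 is estimated at 200000 nM, between 60000 nM and 400000 nM, most likely reported again as a limit.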

Compound 3, half-maximal inhibitory concentration: > 200000 nM
Compound 3 was reported as a limit; the forecaster's own chance of this, stated with the estimate: 75%; the middle value sits exactly at the limit.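

In this assay compound 3 gives > 200000 nM, a limit of the assay. For the compounds shown here, no step between compound 2 and compound 3 can be read from the two limits. The compounds shown leave open whether any side chain on the shared core gives a measurable potency: the limit of > 200000 nM in this assay, at which 3 of the 3 values shown sit.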